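Phenyl in place of hydrogen on the aryl ring

The source may hold more compounds than are shown below. What is called first, only, known or untested is meant among the compounds shown, and "the series" means these compounds.

Among the compounds with values here, compound 2 `CN(CC1=CC[C@H]2C[C@@H]1C2(C)C)Cc1ccccc1` gives 15800 nM in an assay on HEK293 cells for displacement of a labelled ligand from C-X-C chemokine receptor type 3 (Homo sapiens) (on this read-out lower numbers stand for stronger inhibition and higher numbers for weaker inhibition), the highest of the two numbers known; its nearest neighbour, compound 1 `CN(CC1=CC[C@H]2C[C@@H]1C2(C)C)Cc1cccc(I)c1`, gives 7940 nM in this assay. Within the data shown here, the only step measured, a 2.0-fold higher number from compound 1 to compound 2 (0.30 log units; within the scatter), lies within the scatter. Compound 3 `CN(CC1=CC[C@H]2C[C@@H]1C2(C)C)Cc1cccc(-c2ccccc2)c1` differs from compound 2 by phenyl in place of hydrogen on an aromatic carbon, at the place where compound 1 carries iodo. Because that single step, a 2.0-fold higher number from compound 1 to compound 2 (0.30 log units; within the scatter), stayed within the scatter, only a small lowering at most is expected. The expected step for compound 3 is a 3.2-fold lower number from compound 2 to compound 3 (0.50 log units; beyond the scatter). Compound 3 is estimated at 5000 nM, within 1500 nM to 16000 nM.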

Compound 3, inhibition constant: > 316 nM
Compound 3 gave a limit, no number; the forecaster's own chance of this, stated with the estimate: 10%; the middle value lies beyond the limit too.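

Compound 3 gives > 316 nM, which is a limit and not a number, so the steps to it from compound 1 and compound 2 cannot be read. The compounds shown leave open whether phenyl in place of hydrogen strengthens inhibition, weakens it or leaves it unchanged.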